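Inverting both ring stereocentres of compound 1

This account rests on a few compounds, and the source may have more. Where it says the series, first, only, none or still open, it means among the compounds named here.

Measured in a functional assay on HL-60 cells (Homo sapiens) for inhibition, read by CCK-8 assay, with a stated time of 48 h; a lower number here means a stronger inhibitor, a higher number a weaker inhibitor
Compound 1 `O=C(NCCNS(=O)(=O)c1ccc(-c2ccccc2O[C@H]2CC[C@H](O)CC2)s1)Nc1cc(C(F)(F)F)cc(C(F)(F)F)c1` gives 7100 nM
Compound 2 `COc1ccc(NC(=O)NCCNS(=O)(=O)c2ccc(-c3ccccc3OCc3ccccc3)s2)cc1` gives > 50000 nM (a limit)

Among the compounds with values here, compound 1 at 7100 nM holds the only actual number so far in this assay and nothing yet ranks it. For compound 2 the entry > 50000 nM is a limit and not a number.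

Compound 3 `O=C(NCCNS(=O)(=O)c1ccc(-c2ccccc2O[C@H]2CC[C@@H](O)CC2)s1)Nc1cc(C(F)(F)F)cc(C(F)(F)F)c1` keeps the atoms and bonds of compound 1 and differs only in configuration as drawn (the two compounds have the same atoms and bonds and differ only in configuration as drawn: 2 of 2 stereo elements differ (all stereocentres are inverted: mirror images); a stereocentre at a saturated ring carbon is drawn r in compound 1 and s in compound 3; a stereocentre at a saturated ring carbon is drawn r in compound 1 and s in compound 3). Within the data shown here, no measured step shows what such a change does, so the expected shift has no direction and stays within the usual scatter (a 1.0-fold lower number from compound 1 to compound 3 (0.01 log units; within the scatter)). For compound 3 the expected value in this assay is 7000 nM with an estimated range (2500 nM to 20000 nM).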

Compound 3, half-maximal inhibitory concentration: 3100 nM
The estimate for compound 3 lay 2.3-fold (0.35 log units) above the measured number; the range from low to high includes it.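

Configuration at the saturated ring carbons counts in this assay, with a 2.3-fold lower number from compound 1 to compound 3 (0.36 log units; beyond the scatter), a modest step but one that no earlier comparison could show. The shift is tied to those two ring carbons alone, because of one fact: the fact that compounds 1 and 3 differ only in the configuration as drawn

This single pair leaves open whether the same preference would hold with a different group on the urea. It also leaves open what an amine or a carboxylic acid in place of the hydroxyl on that ring would do in either configuration.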